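The source may hold more compounds than are shown below. What is called first, only, known or untested is meant among the compounds shown, and "the series" means these compounds.

Measured in a functional assay on the whole organism for inhibition, with Scenedesmus acutus as the target; on this read-out higher numbers stand for weaker inhibition and lower numbers for stronger inhibition:

- Compound 1 `O=C(O)c1cc(N2C(=O)C3=C(CCCC3)C2=O)ccc1Cl`: > 100000 nM (a limit of the assay)
- Compound 2 `COC(=O)c1cc(N2C(=O)C3=C(CCCC3)C2=O)ccc1Cl`: 1780 nM
- Compound 3 `CCOC(=O)c1cc(N2C(=O)C3=C(CCCC3)C2=O)c(F)cc1Cl`: 57.5 nM

Compound 3, at 57.5 nM, has the lowest number of the series, and so the strongest inhibition shown. The nearest numerical value belongs to compound 2, at 1780 nM. The value of compound 1 is only a limit, as the limit of > 100000 nM in this assay, at which 1 of the 3 values shown sits, records.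

The next compound is compound 4 `CCOC(=O)c1cc(N2C(=O)C3=C(CCCC3)C2=O)ccc1Cl`, still to be measured in this assay. It has hydrogen in place of fluoro on an aromatic carbon.

Among the compounds with values here, only one measured step is available, the large drop an at least 56-fold lower number from compound 1 to compound 2 (1.74 log units; beyond the scatter). That step is methyl in place of hydrogen on an oxygen next to a carbonyl group, so it gives no direct size for losing the fluoro. The expectation therefore rests mainly on the values themselves. Compound 4 keeps the ethoxycarbonyl group of compound 3, whose value of 57.5 nM is the lower anchor, while compound 2 at 1780 nM suggests the upper region.

A moderate move to a higher number, meaning weaker inhibition, is expected, and the estimated step is a 7.8-fold higher number from compound 3 to compound 4 (0.89 log units; beyond the scatter). For compound 4 the estimated value is 450 nM, with an expected range from 110 nM to 1800 nM.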

Compound 4, half-maximal inhibitory concentration: 1910 nM
The estimate for compound 4 lay 4.2-fold (0.63 log units) below the measured number, outside the stated range (above it).
By their numbers in this assay, from the lowest: compound 3; then compounds 2 and 4 (each within the scatter of the next). At a limit, above all of these: compound 1.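

In this assay, within the data shown here, the fluoro para to an ethoxycarbonyl group and meta to a chloro group proves to be a major contributor to the inhibition seen with compound 3: hydrogen in its place gives a 33-fold higher number from compound 3 to compound 4 (1.52 log units; beyond the scatter), the first measured step at this position. With hydrogen at this position, the ester chain does not separate the two esters, with methyl in place of hydrogen on the saturated chain carbon giving a 1.1-fold higher number from compound 2 to compound 4 (0.03 log units; within the scatter), so the low number of compound 3 cannot be credited to the ethyl ester alone. With ethyl in place of hydrogen on the oxygen next to the carbonyl group, the step of an at least 52-fold lower number from compound 1 to compound 4 (1.71 log units; beyond the scatter) starts from a limit of the assay and not from a number: the limit of > 100000 nM in this assay, at which 1 of the 4 values shown sits.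

The compounds shown leave open whether fluoro would give a step of similar size on the methyl ester, and whether the ethyl ester adds anything once fluoro is present. They also leave open whether this position responds only to fluoro or also to a bromo, methoxy or nitrile group, and how a longer chain such as propyl on the ester oxygen would read.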